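Shortening the Amine Side Arm on a Shared Core

A few compounds are considered here, and "the series" means these few. Any claim that something is new, unique, unknown or untested is made for them only; others in the source may bear on it.

Compound 1 `CC(C)NCc1nnc(-c2ccccc2-c2ccccc2)s1`: 35 mg/kg
Compound 2 `c1ccc(CNCc2nnc(-c3ccccc3-c3ccccc3)s2)cc1`: 29 mg/kg
Compound 3 `Cc1ccccc1NCc1nnc(-c2ccccc2-c2ccccc2)s1`: > 200 mg/kg, which is a limit of the assay and not a number

In a functional assay on the whole organism with Mus musculus as the target (on this read-out lower numbers stand for an effect already at smaller amounts and higher numbers for an effect only at larger amounts of compound), compound 1 gives 35 mg/kg, the higher of the two numbers available, yet its nearest neighbour is within the scatter: a 1.2-fold lower number from compound 1 to compound 2 (0.08 log units; within the scatter). For compound 3 only a limit was reached (the limit of > 200 mg/kg in this assay, at which 1 of the 3 values shown sits). The steps of an at least 5.7-fold higher number from compound 1 to compound 3 (0.75 log units; beyond the scatter) and an at least 6.8-fold higher number from compound 2 to compound 3 (0.83 log units; beyond the scatter) are both beyond the scatter, so placing a 2-methylphenyl on the amine nitrogen removes the effect, while exchanging isopropyl for benzyl there does not matter.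

Compound 4 `CC(N)c1nnc(-c2ccccc2-c2ccccc2)s1` differs from compound 1 by 1-aminoethyl in place of (isopropylamino)methyl on an aromatic carbon. Within the data shown here, no measured step shortens the arm or strips the amine nitrogen of its substituent, so none bears directly on this change; the measured steps only show that the nitrogen tolerates alkyl or benzyl and not an aryl group. A step of modest size in either direction, most likely toward a somewhat higher number, is therefore expected: a 1.6-fold higher number from compound 1 to compound 4 (0.20 log units; within the scatter). Compound 4 is estimated at 55 mg/kg, within a range from 20 mg/kg to 160 mg/kg.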

Compound 4, dose for half-maximal effect: 32 mg/kg
Compound 4: middle estimate off by 1.7-fold (0.24 log units), on the high side; low and high end bracket the measured number.
By their numbers in this assay, from the lowest: compounds 2, 4 and 1 (each within the scatter of the next). At a limit, above all of these: compound 3.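

In this assay, putting 1-aminoethyl in place of (isopropylamino)methyl on this aromatic carbon gives a 1.1-fold lower number from compound 1 to compound 4 (0.04 log units; within the scatter), so an arm of 3 heavy atoms serves as well here as one of 5. The earlier compounds changed only the group on the amine nitrogen, whereas compound 4 shows that the effect survives with no substituent on that nitrogen at all, so a substituent there is not required, and of the compounds shown only compound 3, with its 2-methylphenyl, goes against this tolerance. Nothing measured here explains why the shorter arm and the longer one read alike.

Whether the amine itself is needed stays open, since every arm shown carries one, and a hydroxymethyl or a carboxylic acid at this position would test that. Going by these compounds, how far the arm can grow or shrink also stays open, for example with a longer chain such as 3-aminopropyl.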